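This account rests on a few compounds, and the source may have more. Where it says the series, first, only, none or still open, it means among the compounds named here.

In an ADME assay on microsomes from liver (Homo sapiens) for metabolic stability, read by LC-MS, tested at 1 uM (on this read-out lower numbers stand for slow clearance and higher numbers for fast clearance), compound 1 `NCCOc1ccc([C@H]2CC[C@]3(CC2)OOC2(O3)C3CC4CC(C3)CC2C4)cc1` gives < 7 mL.min-1.g-1, which is a limit of the assay and not a number. Among the measured compounds shown here, compound 2 `c1cc([C@H]2CC[C@]3(CC2)OOC2(O3)C3CC4CC(C3)CC2C4)ccc1OC1CCNCC1` gives 15 mL.min-1.g-1, the only actual number so far. Compound 3 `CC1(C)CC(O)(COc2ccc([C@H]3CC[C@]4(CC3)OOC3(O4)C4CC5CC(C4)CC3C5)cc2)CC(C)(C)N1` differs from compound 2 by (4-hydroxy-2,2,6,6-tetramethylpiperidin-4-yl)methyl in place of piperidin-4-yl on an oxygen on an aromatic ring. For the measured compounds named here, the one measured step at this place is an at least 2.1-fold higher number from compound 1 to compound 2 (0.33 log units; beyond the scatter), at least modest and beyond the scatter. One end of that step is the limit of < 7 mL.min-1.g-1 in this assay, at which 1 of the 2 values shown sits. Going by the values given here, no measured step carries the entering group, so the expectation stays anchored on compound 2 at 15 mL.min-1.g-1, with no step beyond the scatter expected in this assay and no direction favoured. The expected step is no change at the digits printed from compound 2 to compound 3 (within the scatter). The estimate for compound 3 is 15 mL.min-1.g-1, with an expected range from 7 mL.min-1.g-1 to 40 mL.min-1.g-1.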

Compound 3, intrinsic clearance in microsomes: 14 mL.min-1.g-1
For compound 3 the middle estimate is 1.1-fold (0.03 log units) above the measured one, within the range that was stated.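

In this assay, the position on an oxygen on an aromatic ring accepts (4-hydroxy-2,2,6,6-tetramethylpiperidin-4-yl)methyl, with 12 heavy atoms, in place of piperidin-4-yl, with 6, and the read-out gives a 1.1-fold lower number from compound 2 to compound 3 (0.03 log units; within the scatter). The two ring amines therefore cannot be told apart in this assay, although the entering group also adds a hydroxy group and methyl groups. Against the short chain the result is an at least 2.0-fold higher number from compound 1 to compound 3 (0.30 log units; that floor lies within the scatter), and compound 1 holds the only limit among these values: the limit of < 7 mL.min-1.g-1 in this assay, at which 1 of the 3 values shown sits.

The compounds shown leave open whether the hydroxy group and the methyl groups each leave the read-out unchanged when present alone. They also leave open what a non-amine group, such as a carboxylic acid or an amide, would give at this oxygen.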